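Replacing the imidazole group of compound 2

The source may report more compounds than this note shows. Statements on the series, on what has been measured and on what is new or still open speak of the compounds shown alone.

- Compound 1 `O=c1[nH]/c(=C\c2nc[nH]c2C2CC2)c(=O)[nH]/c1=C\c1cccc(Oc2ccc(F)cc2)c1`: 15.2 nM
- Compound 2 `O=C(c1ccc(F)cc1)c1cccc(/C=c2\[nH]c(=O)/c(=C/c3nc[nH]c3C3CC3)[nH]c2=O)c1`: 2.8 nM
- Compound 3 `O=c1[nH]/c(=C\c2cccs2)c(=O)[nH]/c1=C\c1cccc(Oc2ccc(F)cc2)c1`: > 1000 nM (a limit, not a number)

In a functional assay on NCI-H460 cells (Homo sapiens) for cytotoxicity, read by MTT assay, with a stated time of 72 h (a lower number here means a stronger inhibitor, a higher number a weaker inhibitor), compound 2 gives the lowest of the two true numbers, reached by a 5.4-fold lower number from compound 1 to compound 2 (0.73 log units; beyond the scatter). Compound 4 `Cc1ccc(/C=c2\[nH]c(=O)/c(=C/c3cccc(C(=O)c4ccc(F)cc4)c3)[nH]c2=O)o1` puts 5-methylfuran-2-yl in place of 5-cyclopropyl-1H-imidazol-4-yl on a double-bonded chain carbon bound to an aromatic carbon. The closest guide is an at least 65-fold higher number from compound 1 to compound 3 (1.81 log units; beyond the scatter), where the same group leaves, but thiophen-2-yl enters instead and the partner group is 4-fluorophenoxy. From the compounds shown here alone, that step ends at a limit for compound 3, so its true size is unknown. A large rise in the number is therefore expected in this assay, namely a 110-fold higher number from compound 2 to compound 4 (2.03 log units; beyond the scatter). Compound 4 is estimated at 300 nM, with an expected range of 50 nM to 2000 nM.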

Compound 4, half-maximal inhibitory concentration: 5.3 nM
For compound 4 the middle estimate is 57-fold (1.75 log units) above the measured one; the measured number lies below the stated range.
By their numbers in this assay, from the lowest: compounds 2 and 4 (each within the scatter of the next); then compound 1. At a limit, above all of these: compound 3.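

In this assay, 5-methylfuran-2-yl in place of 5-cyclopropyl-1H-imidazol-4-yl gives a 1.9-fold higher number from compound 2 to compound 4 (0.28 log units; within the scatter), so the imidazole and its hydrogen-bond donor are not required here when the partner group is (4-fluorophenyl)carbonyl. The loss seen with thiophen-2-yl and a 4-fluorophenoxy partner, an at least 65-fold higher number from compound 1 to compound 3 (1.81 log units; beyond the scatter), therefore does not extend to every replacement of this group. Compound 3 stands at a limit, not a number: the limit of > 1000 nM in this assay, at which 1 of the 4 values shown sits.

No pair shown separates the effect of the entering ring from that of the partner group. From the compounds shown here alone, how an amine or a carboxylic acid would behave at this place also stays open.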